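The source may report more compounds than this note shows. Statements on the series, on what has been measured and on what is new or still open speak of the compounds shown alone.

Measured compounds:

compound 1 `COc1ccc(C2=Cc3ccc(F)cc3C(CC(=O)CO)N2c2ccc(Cl)cc2)cc1` — 8500 nM
compound 2 `COc1ccc(C2=Cc3ccc(F)cc3C(CC(=O)CO)N2c2ccc(C#N)cc2)cc1` — 39700 nM
compound 3 `COc1ccc(C2=Cc3ccc(F)cc3C(CC(=O)CO)N2c2ccc([N+](=O)[O-])cc2)cc1` — 46400 nM

All three were tested in an ADME assay on TZM cells (Homo sapiens) for cytotoxicity, read by CellTiter-Glo, with a stated time of 48 h; a higher number here means that more compound is tolerated, a lower number that less compound is tolerated. Among them, compound 1 stands at the lowest number, so the least compound is tolerated; compound 2 lies at a 4.7-fold higher number from compound 1 to compound 2 (0.67 log units; beyond the scatter) and compound 3 at a 5.5-fold higher number from compound 1 to compound 3 (0.74 log units; beyond the scatter), both beyond the scatter. Between compound 2 and compound 3 the step is a 1.2-fold higher number from compound 2 to compound 3 (0.07 log units; within the scatter), which is within the scatter, so no order can be read between those two.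

Compound 4 `COc1ccc(C2=Cc3ccc(F)cc3C(C[N+](=O)[O-])N2c2ccc(Cl)cc2)cc1` has not yet been measured. It differs from compound 1 in one place: nitro in place of (hydroxymethyl)carbonyl on a saturated chain carbon bound to a saturated ring carbon. Every measured step changes only the group on the aromatic ring that carries the chloro, cyano or nitro group; none touches the chain on the saturated ring carbon. Among the measured compounds shown here, no measured step therefore bears on this change, and there is nothing to point to a step beyond the scatter in either direction. Compound 4 is expected to give roughly the number of compound 1, an estimated step of a 1.1-fold higher number from compound 1 to compound 4 (0.02 log units; within the scatter), with the estimate for compound 4 being 9000 nM in a range from 3000 nM to 30000 nM.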

Compound 4, half-maximal cytotoxic concentration: 32200 nM
Estimate against measurement, compound 4: 3.6-fold (0.55 log units) below; measured number above the stated range.
By their numbers in this assay, from the lowest: compound 1; then compounds 4, 2 and 3 (each within the scatter of the next).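

In this assay, among the compounds shown here, the chain on the saturated ring carbon also moves the number, a place that none of the earlier steps touched. Nitro in place of (hydroxymethyl)carbonyl on this chain gives a 3.8-fold higher number from compound 1 to compound 4 (0.58 log units; beyond the scatter), with the chloro group on the aromatic ring held fixed. The leaving group carries a hydrogen-bond donor and nitro carries none, but no measurement shown explains the rise.

A single replacement cannot show whether the step comes from adding nitro or from losing (hydroxymethyl)carbonyl, and an amine, a carboxylic acid or a longer chain at this place could help separate the two. On these data alone, it also remains open whether the same change gives a similar step when cyano or nitro takes the place of chloro on the aromatic ring.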